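The source may hold more compounds than are shown below. What is called first, only, known or untested is meant among the compounds shown, and "the series" means these compounds.

Measured so far:
compound 1 `O=C(CCc1ccccc1)Nc1nc2ccccc2c(=O)s1` — 390 nM
compound 2 `O=C(CCCc1cccc(Cl)c1)Nc1nc2ccccc2c(=O)s1` — > 1000 nM

In an assay on CHO cells for displacement of a labelled ligand from adenosine receptor A3 (Homo sapiens), read by scintillation counting, with a stated time of 60 min (on this read-out lower numbers stand for stronger inhibition and higher numbers for weaker inhibition), compound 1 gives 390 nM. For compound 2 this assay reports only a limit, > 1000 nM, not a number. For the measured compounds named here, the one measured step, an at least 2.5-fold higher number from compound 1 to compound 2 (0.40 log units; beyond the scatter), therefore sets only a floor on the loss. Compound 3 `O=C(CCc1ccc(Cl)c(Cl)c1)Nc1nc2ccccc2c(=O)s1` has not yet been measured; its change is 3,4-dichlorophenyl in place of 3-chlorobenzyl on a saturated chain carbon, two bonds along the chain from a carbonyl carbon. This partly reverses the measured step, since compound 3 shares the shorter chain of compound 1, while carrying two chlorines instead of one, so a modest gain is expected, an at least 2.0-fold lower number from compound 2 to compound 3 (0.30 log units; that floor lies within the scatter). Compound 3 is thus estimated at 500 nM, within 150 nM to 2000 nM.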

Compound 3, inhibition constant: > 1000 nM
Compound 3: no number, only a limit (the forecaster's own chance of this, stated with the estimate: 30%); middle value at least 2.0-fold (0.30 log units) from the limit.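

In this assay compound 3 gives only a limit, > 1000 nM, not a number. With 3,4-dichlorophenyl in place of phenyl at this chain carbon, binding still weakens, with an at least 2.5-fold higher number from compound 1 to compound 3 (0.40 log units; beyond the scatter), so the loss is not confined to the 3-chlorobenzyl group of compound 2. The step between compound 2 and compound 3 cannot be read, as both sit at one limit: the limit of > 1000 nM in this assay, at which 2 of the 3 values shown sit.

From the compounds shown here alone, how far beyond that limit either compound lies stays open. So does whether a single fluorine or a methoxy on the phenyl ring of compound 1 would keep its binding.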